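The compounds below may be only part of what the source reports. "The series", "measured", "known", "first", "only" and "open" are said of these compounds alone.

Compound 1 `Cc1ccc(N/C(=N\C(=O)c2ccccc2)NCc2ccccc2)cc1` gives 876000 nM
Compound 2 `O=C(/N=C(/NCc1ccccc1)Nc1ccc([N+](=O)[O-])cc1)c1ccccc1` gives 802000 nM
Compound 3 `O=C(/N=C(/NCc1ccccc1)Nc1ccc(Br)cc1)c1ccccc1` gives 738000 nM

All three values come from an ADME assay on cells (Peritoneal macrophage, Mus musculus) for cytotoxicity, read by MTT assay, with a stated time of 24 h (a lower number here means that less compound is tolerated, a higher number that more compound is tolerated), and cannot be told apart. Compound 3 stands level with the other two, as its steps show: a 1.2-fold lower number from compound 1 to compound 3 (0.07 log units; within the scatter) and a 1.1-fold lower number from compound 2 to compound 3 (0.04 log units; within the scatter) are its two comparisons. Compound 4 `O=C(/N=C(/NCc1ccccc1)Nc1ccc(Cl)cc1)c1ccccc1` differs from compound 3 by a single swap chloro in place of bromo on an aromatic carbon that puts chloro in place of bromo on an aromatic carbon, para to a large group. The remaining swap at this spot, a 1.1-fold lower number from compound 1 to compound 2 (0.04 log units; within the scatter) as well, also stayed within the scatter. Methyl, nitro and bromo thus gave no real separation, so no change beyond the scatter is expected here. The expected step is a 1.1-fold higher number from compound 3 to compound 4 (0.02 log units; within the scatter) and no more. Compound 4 is estimated at 780000 nM within an expected range of 500000 nM to 1200000 nM in this test.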

Compound 4, half-maximal cytotoxic concentration: 827000 nM
Estimate against measurement, compound 4: 1.1-fold (0.03 log units) below; the measured number falls inside the stated range.
By their numbers in this assay, from the lowest: compounds 3, 2, 4 and 1 (each within the scatter of the next).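

In this assay, chloro in place of bromo, nitro or methyl on this aromatic carbon gives no separation from any of them (a 1.1-fold higher number from compound 3 to compound 4 (0.05 log units; within the scatter); a 1.0-fold higher number from compound 2 to compound 4 (0.01 log units; within the scatter); a 1.1-fold lower number from compound 1 to compound 4 (0.02 log units; within the scatter)). A fourth group at this spot therefore cannot be told apart from the first three, and compounds 1 to 4 show no trend across these groups. No evidence is available that bears on this result. On these data alone, whether an amine, a carboxylic acid or a longer chain here would give a step beyond the scatter stays open. So does the outcome of changes elsewhere on the shared core.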